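Methoxymethyl Capping of a Phenolic Chromone Series

A few compounds are considered here, and "the series" means these few. Any claim that something is new, unique, unknown or untested is made for them only; others in the source may bear on it.

Compound 1 `CC/C=C\C/C=C\C/C=C\CCCCCCCc1cc(=O)c2c(O)cc(O)cc2o1`: 6790 nM
Compound 2 `CC/C=C\C/C=C\C/C=C\CCCCCCCc1cc(=O)c2c(O)cc(OCOC)cc2o1`: 6790 nM
Compound 3 `CC/C=C\C/C=C\C/C=C\CCCCCCCc1cc(=O)c2c(O)c(C)c(O)c(C)c2o1`: 6790 nM

In a functional assay on MDA-MB-231 cells (Homo sapiens) for antiproliferative activity, read by MTT assay (on this read-out higher numbers stand for weaker inhibition and lower numbers for stronger inhibition), compound 1 gives 6790 nM and compound 2 gives 6790 nM. The change between them is methoxymethyl in place of hydrogen on an oxygen on an aromatic ring and it made the step of no change at the digits printed from compound 1 to compound 2 (within the scatter). Compound 3 `CC/C=C\C/C=C\C/C=C\CCCCCCCc1cc(=O)c2c(O)c(C)c(O)c(C)c2o1` gives 6790 nM in this assay; the difference between its core and the core of compound 1 is not broken down here.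

Compound 4 `CC/C=C\C/C=C\C/C=C\CCCCCCCc1cc(=O)c2c(O)c(C)c(OCOC)c(C)c2o1` is yet to be measured. It differs from compound 3 by methoxymethyl in place of hydrogen on an oxygen on an aromatic ring, the same change as from compound 1 to compound 2. Because no change at the digits printed from compound 1 to compound 2 (within the scatter) was flat, the step of no change at the digits printed from compound 3 to compound 4 (within the scatter) is expected to be flat as well. Compound 4 is therefore estimated at 6790 nM, with a likely range of 3400 nM to 13600 nM.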

Compound 4, half-maximal inhibitory concentration: 16100 nM
For compound 4 the middle estimate is 2.4-fold (0.37 log units) below the measured one, and the stated range ends below it.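

In this assay, the change from hydroxy to methoxymethoxy gave a 2.4-fold higher number from compound 3 to compound 4 (0.37 log units; beyond the scatter), against no change at the digits printed from compound 1 to compound 2 (within the scatter) on the other core. Set side by side, the two steps cannot be told apart: the same change on two cores in this assay, no change at the digits printed (within the scatter) from compound 1 to compound 2 and a 2.4-fold higher number (0.37 log units; beyond the scatter) from compound 3 to compound 4, 2.4-fold (0.37 log units) apart, within the scatter of two such steps. This shows that the change carried from one core to the other without a difference beyond the scatter, but it does not show that the two cores respond identically, and two cores are too few to support a rule for the whole series.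

The compounds shown leave open whether a methyl group, an acetyl group or a longer chain carrying an amine, in place of methoxymethyl, would give a similar step on either core.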